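Ester chain change in a small three-compound series

The source may hold more compounds than are shown below. What is called first, only, known or untested is meant among the compounds shown, and "the series" means these compounds.

Of the compounds shown here, three share one core and have been measured in an assay on membranes from HeLa cells for displacement of a labelled ligand from adenosine receptor A3 (Homo sapiens), read by scintillation counting, with a stated time of 180 min, tested at 1 uM; on this read-out lower numbers stand for less inhibition and higher numbers for more inhibition at the one concentration tested (going by the name of the read-out). Compound 1 `CCCOC(=O)C1=C(C)NC(=O)NC1c1ccoc1` gives 11% there. Compound 2 `CC(=O)C1=C(C)NC(=O)NC1c1ccoc1` gives 2% in this assay, and compound 3 `CC1=C(C(=O)OC2CCC2)C(c2ccoc2)NC(=O)N1` gives 1%. Compound 3 is the reference for the next step: the steps of a number 10 percentage points lower from compound 1 to compound 3 (within the scatter) and a number 1 percentage points lower from compound 2 to compound 3 (within the scatter) both fall within the scatter, as does a number 9 percentage points lower from compound 1 to compound 2 (within the scatter), so the three numbers cannot be told apart on this read-out.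

Compound 4 `CC1=C(C(=O)OCC2CCC2)C(c2ccoc2)NC(=O)N1` differs from compound 3 by cyclobutylmethyl in place of cyclobutyl on an oxygen next to a carbonyl group. The measured step that bears on it most is the other change on an oxygen next to a carbonyl group, a number 10 percentage points lower from compound 1 to compound 3 (within the scatter), which lay within the scatter; a number 1 percentage points lower from compound 2 to compound 3 (within the scatter), a change on the carbonyl carbon, lay within it as well. No measured change at this position moves the read-out beyond the scatter, so the expected step is a number 3 percentage points higher from compound 3 to compound 4 (within the scatter), nothing beyond the scatter in either direction. Compound 4 is therefore estimated at 4% in this assay, with a range from -6% to 14%.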

Compound 4, a percentage reported as inhibition, at one concentration (the size of the read-out at that concentration, not a potency): 2%
Compound 4: middle estimate off by 2 percentage points, on the high side; low and high end bracket the measured number.
By their numbers in this assay, from the lowest: compounds 3, 2, 4 and 1 (each within the scatter of the next).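

In this assay, cyclobutylmethyl in place of cyclobutyl on an oxygen next to a carbonyl group gives a number 1 percentage points higher from compound 3 to compound 4 (within the scatter) and shows that this change, which keeps the four-membered ring, does not separate the pair. The comparisons with the other two compounds, no change at the digits printed from compound 2 to compound 4 (within the scatter) and a number 9 percentage points lower from compound 1 to compound 4 (within the scatter), also stay inside the scatter, so all four compounds remain indistinguishable on this read-out. Nothing available explains these numbers.

Going by these compounds, whether any group at this position can move inhibition beyond the scatter at the one concentration tested remains open. A benzyl group or a longer chain on the oxygen, or an amine in place of the alkoxy group on the carbonyl carbon, could address that question.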